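A few compounds are considered here, and "the series" means these few. Any claim that something is new, unique, unknown or untested is made for them only; others in the source may bear on it.

Values so far in a functional assay on MDA-MB-231 cells (Homo sapiens) for antiproliferative activity, read by MTT assay, with a stated time of 48 h; on this read-out lower numbers stand for stronger inhibition and higher numbers for weaker inhibition:
- compound 1 `CN1CCN(c2ccc(-c3cc4c(N5CCN(S(=O)(=O)/C=C/c6ccccc6)CC5)ncnc4s3)cc2)CC1` gives 5900 nM
- compound 2 `COc1ccc(NC(=O)N2CCN(c3ncnc4sc(-c5ccc(N6CCN(C)CC6)cc5)cc34)CC2)cc1` gives 20900 nM
- compound 3 `CN1CCN(c2ccc(-c3cc4c(N5CCN(C(=O)Nc6ccc(C#N)cc6)CC5)ncnc4s3)cc2)CC1` gives 3930 nM

Compound 3 shares the low end of these numbers with compound 1, the two being separated only by a 1.5-fold lower number from compound 1 to compound 3 (0.18 log units; within the scatter) and so lying within the scatter of each other. Compound 2 stands apart from compound 1, with a 3.5-fold higher number from compound 1 to compound 2 (0.55 log units; beyond the scatter) on that side.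

Compound 4 `COc1ccccc1NC(=O)N1CCN(c2ncnc3sc(-c4ccc(N5CCN(C)CC5)cc4)cc23)CC1` differs from compound 3 as follows: 2-methoxyphenyl in place of 4-cyanophenyl on an amide-type nitrogen. The closest measured step is a 5.3-fold lower number from compound 2 to compound 3 (0.73 log units; beyond the scatter) on putting cyano in place of methoxy on an aromatic carbon. Going by the values given here, compound 4 reverses that exchange, but its 2-methoxyphenyl is not the 4-methoxyphenyl of compound 2, and no measured compound shows what that difference does. A modest rise is therefore expected, probably smaller than the measured step. The expected step is a 2.8-fold higher number from compound 3 to compound 4 (0.45 log units; beyond the scatter) in this assay on this reasoning. For compound 4 the estimated value is 11000 nM within a range of 4000 nM to 28000 nM as expected here.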

Compound 4, half-maximal inhibitory concentration: 23200 nM
For compound 4 the middle estimate is 2.1-fold (0.32 log units) below the measured one; measured number inside the range.
By their numbers in this assay, from the lowest: compounds 3 and 1 (each within the scatter of the next); then compounds 2 and 4 (each within the scatter of the next).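

In this assay, going by these compounds alone, the 2-methoxyphenyl and 4-methoxyphenyl groups on the amide-type nitrogen cannot be told apart (a 1.1-fold higher number from compound 2 to compound 4 (0.05 log units; within the scatter)), so within these two compounds the place of the methoxy shows no effect, which the earlier compounds could not show. The exchange for 4-cyanophenyl now gives a rise with a second methoxy compound (a 5.9-fold higher number from compound 3 to compound 4 (0.77 log units; beyond the scatter)), so the lower number of compound 3 no longer rests on compound 2 alone. Going from the sulfonyl group to the methoxy-bearing carbamoyl group also raises the number (a 3.9-fold higher number from compound 1 to compound 4 (0.59 log units; beyond the scatter)).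

Open, as far as these compounds go, is whether an unsubstituted phenyl or a 4-aminophenyl on that nitrogen would sit with compound 3 or with compound 4. The data at hand offer no measurement that explains these differences.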